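Aryl group on sulfur: compound 3 to compound 4

A few compounds are considered here, and "the series" means these few. Any claim that something is new, unique, unknown or untested is made for them only; others in the source may bear on it.

Measured in a functional assay on DU-145 cells (Homo sapiens) for antiproliferative activity, read by propidium iodide staining, with a stated time of 96 h; on this read-out higher numbers stand for weaker inhibition and lower numbers for stronger inhibition:
- compound 1 `CC(O)(CSc1ccc(C(F)(F)F)cc1)C(=O)Nc1ccc(S(F)(F)(F)(F)F)cc1` gives 28800 nM
- compound 2 `CC(O)(CSc1cccc(C(F)(F)F)c1)C(=O)Nc1ccc(S(F)(F)(F)(F)F)cc1` gives 26200 nM
- compound 3 `CC(O)(CSc1ccccc1C(F)(F)F)C(=O)Nc1ccc(S(F)(F)(F)(F)F)cc1` gives 15800 nM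

In this assay compound 3 at 15800 nM stands within the scatter of both other compounds, so the three form one level. Compound 4 `CC(O)(CSc1ccc(C(F)(F)F)cn1)C(=O)Nc1ccc(S(F)(F)(F)(F)F)cc1` is still unmeasured. Its change is 5-(trifluoromethyl)pyridin-2-yl in place of 2-(trifluoromethyl)phenyl on a sulfur. Within the data shown here, three measured steps bear on it: a 1.1-fold lower number from compound 1 to compound 2 (0.04 log units; within the scatter), a 1.8-fold lower number from compound 1 to compound 3 (0.26 log units; within the scatter) and a 1.7-fold lower number from compound 2 to compound 3 (0.22 log units; within the scatter). All stay within the scatter, but none involves a ring with a hetero atom, so the range is kept wide. No step beyond the scatter is expected, in either direction. The expected step is a 1.4-fold higher number from compound 3 to compound 4 (0.14 log units; within the scatter). For compound 4 the estimate is 22000 nM, with an expected range from 8000 nM to 55000 nM.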

Compound 4, half-maximal inhibitory concentration: 30700 nM
Beside the measured number, compound 4's estimate is 1.4-fold (0.14 log units) below it, within the range that was stated.
By their numbers in this assay, from the lowest: compounds 3, 2, 1 and 4 (each within the scatter of the next).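

In this assay a ring with a hetero atom now stands on the sulfur, and 5-(trifluoromethyl)pyridin-2-yl gives a 1.9-fold higher number from compound 3 to compound 4 (0.29 log units; within the scatter) and a 1.2-fold higher number from compound 2 to compound 4 (0.07 log units; within the scatter) and a 1.1-fold higher number from compound 1 to compound 4 (0.03 log units; within the scatter) against the three trifluoromethylphenyl isomers. All four compounds therefore form one level, so this change of ring does not separate compound 4 from compounds 1 to 3. No measurement is at hand that bears on this result.

From the compounds shown here alone, whether an amine or a carboxylic acid on the ring would leave this level stays open. So does the effect of a saturated cyclohexyl group on the sulfur.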